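A few compounds are considered here, and "the series" means these few. Any claim that something is new, unique, unknown or untested is made for them only; others in the source may bear on it.

Compound 1 `CN1CCN(CCNC(=O)n2c(=O)n(Cc3ccccc3)c3ccccc32)CC1` is the point of departure. In a functional assay for agonist activity at 5-hydroxytryptamine receptor 4 (Cavia porcellus) (on this read-out lower numbers stand for smaller maximal responses and higher numbers for larger maximal responses), compound 1 gives no number, only a limit of the assay, < 0.3. Two measured relatives share its core. Compound 2 `CC(C)n1c(=O)n(C(=O)NCCN2CCN(C)CC2)c2cc(Cl)ccc21` reaches 0.7 in this assay. Compound 3 `COc1ccc2c(c1)n(C(=O)NCCN1CCN(C)CC1)c(=O)n2C(C)C` gives in this assay only a limit of the assay, < 0.3. Going by the values given here, the single step measured between neighbours, a number at least 0.40 lower from compound 2 to compound 3 (beyond the scatter), concerns a substituent on the aromatic ring and rests on a limit, as set out in the limit of < 0.3 in this assay, at which 2 of the 3 values shown sit. Compound 4 `CCCn1c(=O)n(C(=O)NCCN2CCN(C)CC2)c2ccccc21` differs from compound 1 elsewhere: ethyl in place of phenyl on a saturated chain carbon bound to an aromatic nitrogen. Among the compounds with values here, no measured step touches that position, so the change from compound 2 to compound 3 offers no direct guide; all that can be said is that compound 2, which also carries a small alkyl group on that nitrogen, gives 0.7. As compound 1 itself stands at a limit, the size of the step to compound 4 has no anchor. Compound 4 is therefore expected to give about 0.4 in this assay, in the range 0.2 to 0.7. The expected step a number at least 0.10 higher from compound 1 to compound 4 (that floor lies within the scatter) is accordingly held loosely.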

Compound 4, intrinsic activity: the largest response reached, as a fraction of the reference agonist's: 0.48
Estimate against measurement, compound 4: 0.080 below, within the range that was stated.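

In this assay, going by these compounds alone, ethyl in place of phenyl on a saturated chain carbon bound to an aromatic nitrogen gives a number at least 0.18 higher from compound 1 to compound 4 (beyond the scatter), the first measured step at this position. The group at this place therefore moves the maximal response on its own, with no substituent on the aromatic ring, something compound 2 and compound 3 could not show, as both carry one. The true size of the step stays unknown and only its floor can be read: the limit of < 0.3 in this assay, at which 2 of the 4 values shown sit.

The compounds shown hold only benzyl and propyl at this place, which leaves the removal of the phenyl ring and the length of the chain unseparated. From the compounds shown here alone, how a longer chain such as pentyl, or a propyl chain ending in an amine, would read in this assay remains open.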